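A few compounds are considered here, and "the series" means these few. Any claim that something is new, unique, unknown or untested is made for them only; others in the source may bear on it.

Among the measured compounds shown here, compound 3, `CC(C)C[C@H](N)c1cc(C(F)(F)F)ccc1N1CCN(C(=O)CC(C)C(=O)c2ccc(Cl)cc2)CC1`, sits second highest of the three numbers measured so far in an assay on HEK293 cells for displacement of a labelled ligand from Melanocortin receptor 4 (Homo sapiens) (a lower number here means a stronger inhibitor, a higher number a weaker inhibitor), where compound 3 gives 1100 nM. Its nearest neighbour is compound 2, `CC(C)C[C@H](N)c1cc(C(F)(F)F)ccc1N1CCN(C(=O)CSc2ccc(Cl)cc2Cl)CC1`, which in this assay gives 1500 nM; the gap a 1.4-fold lower number from compound 2 to compound 3 (0.13 log units; within the scatter) is within the scatter. Far below both stands compound 1, `Cc1cc(Cl)ccc1CC(C)C(=O)N1CCN(c2ccc(C(F)(F)F)cc2[C@@H](N)CC(C)C)CC1`, which in this assay gives 38 nM.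

Compound 4, `CC(C)C[C@H](N)c1cc(C(F)(F)F)ccc1N1CCN(C(=O)C(C)Cc2ccc(Cl)cc2)CC1`, differs from compound 3 in one place: 1-(4-chlorobenzyl)ethyl in place of 2-((4-chlorophenyl)carbonyl)propyl on a carbonyl carbon. For the measured compounds named here, the group that enters is the one carried by compound 1 without its 2-methyl substituent, so the most telling step is a 29-fold higher number from compound 1 to compound 3 (1.46 log units; beyond the scatter), which runs in the opposite direction and was large. The step of a 39-fold higher number from compound 1 to compound 2 (1.60 log units; beyond the scatter) was of similar size, and neither of those two groups was bettered by the other, as a 1.4-fold lower number from compound 2 to compound 3 (0.13 log units; within the scatter) shows.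

Because compound 1 gives 38 nM with a closely related group in that position, compound 4 is expected to come in well under compound 3, with the step of an 11-fold lower number from compound 3 to compound 4 (1.04 log units; beyond the scatter) expected to be large. Allowing for the missing methyl, compound 4 is estimated at 100 nM, within a range of 30 nM to 350 nM.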

Compound 4, inhibition constant: 47 nM
Estimate against measurement, compound 4: 2.1-fold (0.33 log units) above, and the stated range covers the measured number.
By their numbers in this assay, from the lowest: compounds 1 and 4 (each within the scatter of the next); then compounds 3 and 2 (each within the scatter of the next).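

With 1-(4-chlorobenzyl)ethyl on the carbonyl carbon, the shared core leaves the range of the two weaker compounds in this assay, as a 23-fold lower number from compound 3 to compound 4 (1.37 log units; beyond the scatter) and a 32-fold lower number from compound 2 to compound 4 (1.50 log units; beyond the scatter) show. The earlier compounds shown here could not tell whether the methyl on the aromatic ring of compound 1 was needed for its low number, and a 1.2-fold higher number from compound 1 to compound 4 (0.09 log units; within the scatter) now answers this: hydrogen in place of that methyl leaves the value within the scatter. The result therefore ties the large difference from compounds 2 and 3 to the 1-(4-chlorobenzyl)ethyl group itself rather than to that ring methyl, although the change from compound 3 replaces a whole group, so no single part of it can be singled out.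

No measurement offered here explains why this group and 2-((4-chlorophenyl)carbonyl)propyl lie so far apart. The compounds shown also leave open how this assay would respond to a 1-(4-fluorobenzyl)ethyl group, with fluorine in place of the chlorine, or to a group on the same carbonyl carbon that ends in a carboxylic acid.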